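Ring-nitrogen substituent exchange in an agonist series

The compounds below may be only part of what the source reports. "The series", "measured", "known", "first", "only" and "open" are said of these compounds alone.

compound 1 `CN(C[C@H]1Cc2c(cccc2N2CCN(c3cccc(C(F)(F)F)c3)CC2)CN1)[C@H]1CCCc2cccnc21`: > 30000 nM
compound 2 `CN(C[C@H]1Cc2c(cccc2N2C[C@@H]3C[C@H]2CN3)CN1)[C@H]1CCCc2cccnc21`: > 30000 nM

Both measured compounds were tested in a functional assay on CCRF-CEM cells for agonist activity at C-X-C chemokine receptor type 4 (Homo sapiens), read by calcium flux, with a stated time of 25 min; on this read-out lower numbers stand for an effect already at smaller amounts and higher numbers for an effect only at larger amounts of compound. For compound 1 only a limit is reported, > 30000 nM. For compound 2 also only a limit is reported, > 30000 nM. Among the measured compounds shown here, both values sit at the limit of > 30000 nM in this assay, at which 2 of the 2 values shown sit, so compound 1 stands on no number, only at the limit, and no step between measured compounds can be read.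

Compound 3 `CN(C[C@H]1Cc2c(cccc2N2CCN(c3ccccn3)CC2)CN1)[C@H]1CCCc2cccnc21` differs from compound 1 by pyridin-2-yl in place of 3-(trifluoromethyl)phenyl on an amine nitrogen in a ring. For the measured compounds named here, with no measured step to draw on, no direction beyond the scatter is expected in this assay. The estimate for compound 3 is 40000 nM, between 10000 nM and 150000 nM, most likely again reported only as a limit. The expected step is a step that the limit leaves unreadable from compound 1 to compound 3.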

Compound 3, half-maximal effective concentration: > 30000 nM
Compound 3: only a limit was reported (the forecaster's own chance of this, stated with the estimate: 85%); the middle value is on the limit's open side.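

Compound 1 and compound 3 are both reported only as limits, so no step between them can be read: the limit of > 30000 nM in this assay, at which 3 of the 3 values shown sit.

The compounds shown leave open whether any group on this amine nitrogen gives a measurable value in this assay.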